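Replacing 4-Bromophenyl with Pyridin-3-yl: An Expectation

The source may hold more compounds than are shown below. What is called first, only, known or untested is meant among the compounds shown, and "the series" means these compounds.

Measured so far:
compound 1 `Brc1ccc(-n2cc(CSc3nc4ccccc4s3)nn2)cc1`, 59.2%
compound 2 `O=[N+]([O-])c1ccc(-n2cc(CSc3nc4ccccc4s3)nn2)cc1`, 65.5%

Both compounds were tested in a functional assay on the whole organism (strain Albino Wistar) for inhibition, with Rattus norvegicus as the target, read by paw edema, with stated times of 1 h and 5 h, at a dose of 10 mg/kg by the oral route; on this read-out higher numbers stand for more inhibition at the one dose given (going by the name of the read-out) and lower numbers for less inhibition. Going by the values given here, compound 1 gives the lower of the two numbers, and its only neighbour is compound 2; the step of a number 6.3 percentage points higher from compound 1 to compound 2 (within the scatter) is within the scatter, so the two cannot be ranked. That step exchanges one substituent on the same six-membered ring.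

Compound 3 `c1cncc(-n2cc(CSc3nc4ccccc4s3)nn2)c1` differs from compound 1 in another way: pyridin-3-yl in place of 4-bromophenyl on an aromatic nitrogen. Among the compounds with values here, no measured step covers this kind of exchange of the whole ring; the one step available, nitro for bromo, alters a substituent only, and even that did not move the number beyond the scatter. With nothing pointing either way, the number for compound 3 is expected close to that of compound 1, a step of a number 1.2 percentage points lower from compound 1 to compound 3 (within the scatter) that is expected to stay within the scatter. The estimate for compound 3 is 58%, with a range from 40% to 74%.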

Compound 3, a percentage reported as inhibition, in the whole organism at one dose (the size of the read-out at that dose, not a potency): 56%
The estimate for compound 3 lay 2 percentage points above the measured number; measured number inside the range.
By their numbers in this assay, from the lowest: compounds 3, 1 and 2 (each within the scatter of the next).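

In this assay, replacing the whole ring gives a number 3.2 percentage points lower from compound 1 to compound 3 (within the scatter), so compound 1 and compound 3 cannot be told apart. The earlier step altered only a substituent on the ring, whereas this one shows that, on the aromatic nitrogen of the five-membered ring, 4-bromophenyl can give way to pyridin-3-yl, with one ring nitrogen, one hydrogen-bond acceptor and no bromine, without a difference that can be read at this single dose. Nothing available explains why these two compounds give such similar numbers.

Still open, on these data alone, is whether this position accepts groups of a different kind, such as a phenyl ring bearing a carboxylic acid or an amine, or a longer alkyl chain in place of the ring. As far as these compounds go, whether the other pyridine isomers, pyridin-2-yl and pyridin-4-yl, behave like pyridin-3-yl also remains open.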